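Aryl swap at the fused core: compound 3 to compound 4

The source may hold more compounds than are shown below. What is called first, only, known or untested is meant among the compounds shown, and "the series" means these compounds.

Compound 3 `COc1ccc(-c2ccc3ncn(-c4cc(OC)c(OC)c(OC)c4)c3c2)cc1F` gives 520 nM in a functional assay on MCF7 cells (Homo sapiens) for antiproliferative activity, read by MTT assay, with a stated time of 72 h (a lower number here means a stronger inhibitor, a higher number a weaker inhibitor), the second highest of the three numbers in hand. Compound 1 `COc1cc(-n2cnc3ccc(-c4cccc(N)c4)cc32)cc(OC)c1OC` gives 180 nM, and compound 2 `COc1cc(-n2cnc3ccc(-c4cccc(C)c4C)cc32)cc(OC)c1OC` gives 2150 nM. Compound 4 `CCOc1ccc(-c2ccc3ncn(-c4cc(OC)c(OC)c(OC)c4)c3c2)cc1` carries 4-ethoxyphenyl in place of 3-fluoro-4-methoxyphenyl on an aromatic carbon. All three measured steps vary the same aryl group on the shared core: a 2.9-fold higher number from compound 1 to compound 3 (0.46 log units; beyond the scatter), a 4.1-fold lower number from compound 2 to compound 3 (0.62 log units; beyond the scatter) and a 12-fold higher number from compound 1 to compound 2 (1.08 log units; beyond the scatter). Among the measured compounds shown here, no measured pair bears directly on exchanging 3-fluoro-4-methoxyphenyl for 4-ethoxyphenyl, so the direction is open; a step no larger than the modest ones seen is expected, a 1.3-fold higher number from compound 3 to compound 4 (0.10 log units; within the scatter). Compound 4 is therefore estimated at 650 nM, with a range from 250 nM to 1700 nM.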

Compound 4, half-maximal inhibitory concentration: 1710 nM
Compound 4: the middle estimate sits 2.6-fold (0.42 log units) below what was measured; the measured number lies above the stated range.
By their numbers in this assay, from the lowest: compound 1; then compound 3; then compounds 4 and 2 (each within the scatter of the next).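

Even two aryl groups with the same heavy-atom count are not interchangeable at this position in this assay: a 3.3-fold higher number from compound 3 to compound 4 (0.52 log units; beyond the scatter). The 4-ethoxyphenyl group of compound 4 is not separated from the 2,3-dimethylphenyl group of compound 2, a 1.3-fold lower number from compound 2 to compound 4 (0.10 log units; within the scatter), while the 3-aminophenyl group of compound 1 keeps the lowest number, a 9.5-fold higher number from compound 1 to compound 4 (0.98 log units; beyond the scatter). No supporting data explain these differences.

Compound 3 and compound 4 differ in both the fluorine and the alkoxy chain, so the two changes remain unseparated. As far as these compounds go, a plain 4-methoxyphenyl group would bear on this, and how 3-hydroxyphenyl compares with 3-aminophenyl remains open.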